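This account rests on a few compounds, and the source may have more. Where it says the series, first, only, none or still open, it means among the compounds named here.

- compound 1 `Cc1c2c(n3c1CCCNC[C@H](C)Nc1cc-3ccc1C(N)=O)CC(C)(C)CC2=O` gives 366 nM
- compound 2 `Cc1c2c(n3c1CCCN[C@@H](C)[C@H](C)Nc1cc-3ccc1C(N)=O)CC(C)(C)CC2=O` gives 61 nM
- compound 3 `Cc1c2c(n3c1CCCN(C)[C@@H](C)[C@H](C)Nc1cc-3ccc1C(N)=O)CC(C)(C)CC2=O` gives 133 nM

In a functional assay on U-87MG ATCC cells (Homo sapiens) for antiproliferative activity (a higher number here means a weaker inhibitor, a lower number a stronger inhibitor), compound 3 has the second highest of these three numbers, at 133 nM. Compound 4 `CC(=O)N1CCCc2c(C)c3c(n2-c2ccc(C(N)=O)c(c2)N[C@@H](C)[C@@H]1C)CC(C)(C)CC3=O` carries acetyl in place of methyl on an amine nitrogen in a ring. The closest evidence is the modest change on that same nitrogen, a 2.2-fold higher number from compound 2 to compound 3 (0.34 log units; beyond the scatter). The larger step, a 6.0-fold lower number from compound 1 to compound 2 (0.78 log units; beyond the scatter), lies on a saturated ring carbon and bears on this change less directly. Among the compounds with values here, no measured compound carries an acetyl, so the expectation is loose: a modest step towards a higher number. The estimated step is a 1.8-fold higher number from compound 3 to compound 4 (0.26 log units; within the scatter). Compound 4 is expected at about 240 nM, within an estimated range of 80 nM to 700 nM.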

Compound 4, half-maximal inhibitory concentration: 29 nM
Beside the measured number, compound 4's estimate is 8.3-fold (0.92 log units) above it, and the stated range ends above it.
By their numbers in this assay, from the lowest: compound 4; then compound 2; then compound 3; then compound 1.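

In this assay, acetyl in place of methyl on this amine nitrogen gives a 4.6-fold lower number from compound 3 to compound 4 (0.66 log units; beyond the scatter), so the substituent here decides the direction of the step. Methyl on the same nitrogen gave a 2.2-fold higher number from compound 2 to compound 3 (0.34 log units; beyond the scatter), whereas acetyl in place of hydrogen gives a 2.1-fold lower number from compound 2 to compound 4 (0.32 log units; beyond the scatter), so substitution at this nitrogen is not uniformly unfavourable. No available evidence explains this reversal. From the compounds shown here alone, whether a longer acyl chain such as propanoyl or a methanesulfonyl group on this nitrogen would follow acetyl remains open.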